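The source may report more compounds than this note shows. Statements on the series, on what has been measured and on what is new or still open speak of the compounds shown alone.

In a functional assay on PC-3 cells (Homo sapiens) for antiproliferative activity, read by MTT assay, with a stated time of 24 h (a lower number here means a stronger inhibitor, a higher number a weaker inhibitor), compound 1 `CCn1c(C(=O)N[C@H](C)C(=O)OC)ccc1C(CC)(CC)c1ccc(OCS(=O)(=O)c2ccccc2)c(C)c1` gives only a limit of > 50000 nM and no number. Among the measured compounds shown here, compound 2 `CCn1c(C(=O)NCCCO)ccc1C(CC)(CC)c1ccc(OCS(=O)(=O)c2ccccc2)c(C)c1` gives 11300 nM and is the only compound with a true number so far. Compound 3 `CCn1c(C(=O)NCC(=O)O)ccc1C(CC)(CC)c1ccc(OCS(=O)(=O)c2ccccc2)c(C)c1` alters the same chain, and the change is carboxy in place of 2-hydroxyethyl on a saturated chain carbon bound to an amide-type nitrogen with carboxy in place of 2-hydroxyethyl. For the measured compounds named here, the only measured step on this chain is an at least 4.4-fold lower number from compound 1 to compound 2 (0.64 log units; beyond the scatter) with 3-hydroxypropyl in place of 1-(methoxycarbonyl)ethyl on an amide-type nitrogen, so the carbonyl returning in compound 3 is expected to undo part of that gain. The expected move is a 2.7-fold higher number from compound 2 to compound 3 (0.42 log units; beyond the scatter) toward weaker inhibition in this assay and could end at a limit. The estimate for compound 3 is 30000 nM within a range of 12000 nM to 60000 nM.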

Compound 3, half-maximal inhibitory concentration: 30100 nM
Compound 3: the middle estimate sits 1.0-fold (0.00 log units) below what was measured; the measured number falls inside the stated range.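

In this assay, the end of this chain matters: placing carboxy on the saturated chain carbon bound to the amide-type nitrogen gives a 2.7-fold higher number from compound 2 to compound 3 (0.43 log units; beyond the scatter), so this acid is a poorer chain end than the alcohol of compound 2. The comparison with the ester is much looser, with an at least 1.6-fold lower number from compound 1 to compound 3 (0.22 log units; that floor lies within the scatter). Compound 1 gives only a limit, so that gap has no true size: the limit of > 50000 nM in this assay, at which 1 of the 3 values shown sits.

Carboxymethyl differs from 3-hydroxypropyl in both chain length and end group, and these two changes cannot be separated here. A longer chain ending in carboxy, or a chain ending in an amine, remains an open case.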